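From Aminoethyl to Methylcarbamoyl Side Chain

The source may report more compounds than this note shows. Statements on the series, on what has been measured and on what is new or still open speak of the compounds shown alone.

Compound 1 `NCCSC(c1ccc(Br)cc1)c1ccc(Br)cc1` was examined in an assay on brain (strain Sprague-Dawley) for displacement of a labelled ligand from sodium-dependent dopamine transporter (Rattus norvegicus), read by scintillation counting, with a stated time of 120 min (on this read-out higher numbers stand for weaker inhibition and lower numbers for stronger inhibition), and gave 483 nM, the lowest of the three numbers shown. Compound 2 `NC(=O)C[S+]([O-])C(c1ccccc1)c1cccc(Br)c1` gave 550 nM, within the scatter of compound 1, whereas compound 3 `NC(=O)C[S+]([O-])C(c1cccc(F)c1)c1cccc(F)c1` gave 5930 nM, a number beyond the scatter. Compound 4 `CNC(=O)CSC(c1ccc(Br)cc1)c1ccc(Br)cc1` differs from compound 1 by methylcarbamoyl in place of aminomethyl on a saturated chain carbon bound to a sulfur. Among the measured compounds shown here, no measured pair shows this exact change, but compound 1 with 483 nM and compound 2 with 550 nM sit close together, which suggests that a change of this kind need not move the number far. Compound 4 is therefore expected to show a step of a 1.2-fold higher number from compound 1 to compound 4 (0.09 log units; within the scatter), not clearly beyond the scatter in either direction. The estimated value of compound 4 is 600 nM, with a range of 200 nM to 2000 nM.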

Compound 4, inhibition constant: 3010 nM
Beside the measured number, compound 4's estimate is 5.0-fold (0.70 log units) below it, outside the stated range (above it).
By their numbers in this assay, from the lowest: compounds 1 and 2 (each within the scatter of the next); then compounds 4 and 3 (each within the scatter of the next).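

In this assay, methylcarbamoyl in place of aminomethyl on a saturated chain carbon bound to a sulfur gives a 6.2-fold higher number from compound 1 to compound 4 (0.79 log units; beyond the scatter). Among the compounds shown here, this is the first comparison here that differs in one place, and it shows that inhibition at this position is weakened by this change, by more than the usual scatter. Nothing shown here explains the step.

Going by these compounds, it remains open whether the carbonyl or the methyl on the amide nitrogen accounts for the step. On these data alone, how a primary carboxamide, a carboxylic acid or a longer amine chain would read at this position also remains open.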